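Swapping the amide aryl for a thiazole in a cytotoxicity series

This account rests on a few compounds, and the source may have more. Where it says the series, first, only, none or still open, it means among the compounds named here.

Of the compounds shown here, three that share one core have been tested in an ADME assay on MT4 cells (Homo sapiens) for cytotoxicity, read by MTT assay, with a stated time of 5 days; on this read-out lower numbers stand for higher toxicity in this test and higher numbers for lower toxicity in this test. Compound 1 `Cc1cccc(NC(=O)CSc2snnc2-c2ccc(Br)cc2Br)c1C` gives 241000 nM in this assay. Compound 2 `O=C(CSc1snnc1-c1ccc(Br)cc1Br)Nc1ccccc1Br` carries a 2-bromophenyl on the amide-type nitrogen, and in this assay compound 2 reaches only the limit > 221000 nM, not a number. Compound 3 `O=C(CSc1snnc1-c1ccc(Br)cc1Br)Nc1ccccc1[N+](=O)[O-]` carries a 2-nitrophenyl there, and in this assay compound 3 likewise reaches only the limit > 235000 nM. Compound 3 therefore stands at the edge of what this assay can read, and one further value among the three is also a limit, so it cannot be ranked against its neighbours.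

Compound 4 `O=C(CSc1snnc1-c1ccc(Br)cc1Br)Nc1nccs1` differs from compound 3 in one place: 1,3-thiazol-2-yl in place of 2-nitrophenyl on an amide-type nitrogen.

Among the measured compounds shown here, the steps that bear on this change are all unreadable: a step that the limit leaves unreadable from compound 1 to compound 2, a step that the limit leaves unreadable from compound 1 to compound 3, and a step that the two limits leave unreadable from compound 2 to compound 3, because the limit of > 221000 nM in this assay, at which 1 of the 3 values shown sits, and the limit of > 235000 nM in this assay, at which 1 of the 3 values shown sits, cap the values. For the measured compounds named here, no measured step therefore gives a direction, and every replacement of the amide aryl so far has left toxicity at or near the ceiling. For compound 4 the expected step is an at least 1.0-fold lower number from compound 3 to compound 4 (0.00 log units; that floor lies within the scatter), meaning no change beyond the scatter. Compound 4 is estimated to give 230000 nM in this assay, with a range from 100000 nM to 500000 nM, and most likely only a limit again.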

Compound 4, half-maximal cytotoxic concentration: 87800 nM
The estimate for compound 4 lay 2.6-fold (0.42 log units) above the measured number, and the stated range ends above it.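

Among the compounds shown here, none of the steps among compound 1, compound 2 and compound 3 can be read, so 1,3-thiazol-2-yl on the amide-type nitrogen is the first change at this position to give a readable move in this assay. Set against 2,3-dimethylphenyl, the replacement gives a 2.7-fold lower number from compound 1 to compound 4 (0.44 log units; beyond the scatter), the only one of the new steps with an exact size, and here a lower number stands for higher toxicity in this test. Set against the two aryl groups whose compounds reach only a limit, it gives an at least 2.5-fold lower number from compound 2 to compound 4 (0.40 log units; beyond the scatter) and an at least 2.6-fold lower number from compound 3 to compound 4 (0.42 log units; beyond the scatter), and both sizes are floors rather than exact values.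

On these data alone, with one compound of this kind, it stays open whether the shift belongs to 1,3-thiazol-2-yl in particular or would follow from replacing the six-membered aromatic ring of carbon with any other ring. A pyridin-2-yl or a cyclohexyl on the same nitrogen, or a 1,3-thiazol-2-yl that also carries a methyl group or an amine, would help to separate these possibilities.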